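A few compounds are considered here, and "the series" means these few. Any claim that something is new, unique, unknown or untested is made for them only; others in the source may bear on it.

Three compounds share one core and differ in the aromatic group attached to it. Compound 1 `C1=C(c2cncnc2)CC2CNCC1C2` carries a pyrimidine on that core; in an in vitro assay on SH-EP1 cells for displacement of a labelled ligand from Neuronal acetylcholine receptor; alpha4/beta2 (Homo sapiens) (on this read-out higher numbers stand for weaker inhibition and lower numbers for stronger inhibition), compound 1 gives 0.2 nM. Compound 2 `Clc1ccc(C2=CC3CNCC(C2)C3)nn1` gives 0.4 nM in this assay. Compound 3 `Clc1ccccc1Oc1cncc(C2=CC3CNCC(C2)C3)c1` gives 0.9 nM in this assay. Of the three numbers, compound 3 gives the highest, and its gaps to compound 2 and to compound 1 both lie beyond the usual scatter of repeated measurements, so compound 3 is the weakest binder of the three.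

Compound 4 `COc1ccc(Oc2cncc(C3=CC4CNCC(C3)C4)c2)cc1` has not yet been measured. It differs from compound 3 in one place: 4-methoxyphenyl in place of 2-chlorophenyl on an oxygen on an aromatic ring. Within the data shown here, no pair of measured compounds differs in just one place, so there is no measured step to lean on for this exchange. The outer ring itself is kept and only its substituent is replaced, so the change expected in this assay is small, perhaps a slight rise in the number, and not clearly beyond the scatter. On that basis compound 4 is estimated at 1.5 nM in this assay, with a likely range from 0.4 nM to 6 nM. The step expected from compound 3 to compound 4 is a 1.7-fold higher number from compound 3 to compound 4 (0.22 log units; within the scatter).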

Compound 4, inhibition constant: 1.4 nM
For compound 4 the middle estimate is 1.1-fold (0.03 log units) above the measured one, and the stated range covers the measured number.
By their numbers in this assay, from the lowest: compounds 1 and 2 (each within the scatter of the next); then compounds 3 and 4 (each within the scatter of the next).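

In this assay, exchanging 2-chlorophenyl for 4-methoxyphenyl on an oxygen on an aromatic ring gives a 1.6-fold higher number from compound 3 to compound 4 (0.19 log units; within the scatter), so this read-out does not separate the two compounds. Among these compounds, this is the first exchange at this place that can be read directly, as the earlier compounds differ in the whole aromatic group on the shared core and offer no single-place comparison. It shows that a chlorine can give way to a methoxy group, with the group's location on the outer ring also differing between the two names, and that the entering group can carry one hydrogen-bond acceptor where the leaving group has none, all without a step beyond the scatter. The data shown offer no measurement that would explain this result.

Since the substituent and its location change together here, the step cannot show what each contributes alone; 4-chlorophenyl and 2-methoxyphenyl would pull those two apart. As far as these compounds go, it also remains open how this assay would respond to a group of a different kind on the outer ring, such as an amine or a carboxylic acid, or to a longer chain in place of that ring on the oxygen.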